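A few compounds are considered here, and "the series" means these few. Any claim that something is new, unique, unknown or untested is made for them only; others in the source may bear on it.

The compounds were examined in a functional assay on K562 cells (Homo sapiens) for antiproliferative activity, read by MTT assay, with a stated time of 24 h; a lower number here means a stronger inhibitor, a higher number a weaker inhibitor. Compound 1, `COc1ccc(/C=C/C(=O)c2ccc(OC)c3c2OC(C)(C)C=C3)c(F)c1`, reaches only the edge of what the measurement can report: in this assay compound 1 gives > 10000 nM, a limit rather than a number. Compound 2, `COc1cc(OC)c(OC)cc1/C=C/C(=O)c1ccc(OC)c2c1OC(C)(C)C=C2`, sits at the same kind of limit, and in this assay compound 2 gives > 10000 nM. Compound 3, `COc1ccc(C(=O)/C=C/c2ccc3ccccc3n2)c2c1C=CC(C)(C)O2`, is the single one of the three with a measured number, and in this assay compound 3 gives 3020 nM. Compound 1 therefore stands at the weak end of what is shown, a standing it shares with compound 2, since (the limit of > 10000 nM in this assay, at which 2 of the 3 values shown sit). Within the data shown here, no two measured compounds differ in one place only, so no measured step is available to lean on. The unmeasured compound 4, `COc1ccc(C(=O)/C=C/c2cccs2)c2c1C=CC(C)(C)O2`, differs from compound 1 in one place: thiophen-2-yl in place of 2-fluoro-4-methoxyphenyl on a double-bonded chain carbon bound to a double-bonded chain carbon. The step expected here is an at least 2.0-fold lower number from compound 1 to compound 4 (0.30 log units; that floor lies within the scatter), toward stronger inhibition and of modest size. Compound 4 is expected to give about 5000 nM in this assay, within 1500 nM to 15000 nM.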

Compound 4, half-maximal inhibitory concentration: > 10000 nM
Compound 4 was reported as a limit; the forecaster's own chance of this, stated with the estimate: 40%; middle value at least 2.0-fold (0.30 log units) from the limit.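

In this assay compound 4 gives > 10000 nM, which is a limit and not a number. Among these compounds, compound 1 also stands at a limit, so no step between compound 1 and compound 4 can be read. The compounds shown leave open whether thiophen-2-yl and 2-fluoro-4-methoxyphenyl differ at all in this assay.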